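This account rests on a few compounds, and the source may have more. Where it says the series, first, only, none or still open, it means among the compounds named here.

Measured so far in an assay on ileum with muscarinic acetylcholine receptor M3 (Cavia porcellus) as the target; on this read-out lower numbers stand for stronger inhibition and higher numbers for weaker inhibition:
Compound 1 `Cc1nccn1CCCCCC(C(N)=O)(c1ccccc1)c1ccccc1`: 71.3 nM
Compound 2 `CNC(=O)C(CCn1ccnc1C)(c1ccccc1)c1ccccc1`: 5150 nM
Compound 3 `Cc1ccc(C(CCn2ccnc2C)(C(N)=O)c2ccccc2)cc1`: 24.6 nM

Among these three, compound 3 gives the lowest number in this assay, which here means the strongest inhibition. Its nearest neighbour is compound 1, whose number lies higher by a margin beyond the usual scatter, and compound 2 stands far higher still, also well beyond the scatter. No two of the measured compounds differ in only one place, so none of these gaps can be tied to a single structural change.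

Compound 4 `Cc1nccn1CCC(C(N)=O)(c1ccccc1)C(C)C` is not yet measured. It differs from compound 3 in one place: isopropyl in place of 4-methylphenyl on a saturated chain carbon bound to an aromatic carbon, a carbonyl carbon and a saturated chain carbon. For the measured compounds named here, every measured compound carries two six-membered aromatic rings of carbon only on that chain carbon; compound 4 is the first in which one of them gives way to a short branched chain. Going by the values given here, no measured pair shows what such an exchange does, so the expectation rests on judgement alone. The step from compound 3 to compound 4 is expected to be an 8.1-fold higher number from compound 3 to compound 4 (0.91 log units; beyond the scatter), a move toward weaker inhibition, beyond the scatter. Compound 4 is expected to give about 200 nM in this assay, within a range from 40 nM to 1500 nM.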

Compound 4, antagonist equilibrium constant: 394 nM
For compound 4 the middle estimate is 2.0-fold (0.29 log units) below the measured one, and the stated range covers the measured number.
By their numbers in this assay, from the lowest: compound 3; then compound 1; then compound 4; then compound 2.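

In this assay, this chain carbon proves sensitive to what it carries: exchanging 4-methylphenyl for isopropyl gives a 16-fold higher number from compound 3 to compound 4 (1.20 log units; beyond the scatter), a large move toward weaker inhibition and the first effect in this set that can be tied to a single structural change. The two groups match in having no hydrogen-bond donors or acceptors and no net charge, so the counted differences are that 4-methylphenyl brings a six-membered aromatic ring and 7 heavy atoms, whereas isopropyl brings no ring and 3 heavy atoms. No measurement shown here explains why the number rises.

The compounds shown cannot separate the loss of the ring from the loss of size, since both changes happen together in this single exchange; a cyclohexyl group at this place, a ring of similar size with no aromatic character, would pull the two apart. As far as these compounds go, whether a tert-butyl group or a longer chain there would behave like isopropyl also remains open, as does whether the same exchange has an effect of similar size on the core of compound 1.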